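Removing the propoxy group: an expectation for compound 4

The source may hold more compounds than are shown below. What is called first, only, known or untested is meant among the compounds shown, and "the series" means these compounds.

Measured so far:
compound 1, `Cc1ccc(-c2cc(Cl)cc(C(=O)Nc3nn[nH]n3)n2)cc1`, 10%
compound 2, `COc1cc(C(=O)Nc2nn[nH]n2)nc(-c2ccc(C(C)C)cc2)c1`, 29%
compound 3, `CCCOc1cc(C(=O)Nc2nn[nH]n2)nc(-c2ccc(N)cc2)c1`, 7%

In a functional assay on the whole organism for inhibition, with Rattus norvegicus as the target, at a dose of 0.3 mg/kg by the oral route (a lower number here means a weaker effect, a higher number a stronger effect of the compound at the dose given), compound 3 gives 7%, the lowest of the three numbers. Its nearest neighbour is compound 1, which gives 10%, a number within the scatter of compound 3. Compound 2 gives 29%, a number beyond the scatter above compound 3.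

Compound 4, `Nc1ccc(-c2cccc(C(=O)Nc3nn[nH]n3)n2)cc1`, has not yet been measured in this assay. It differs from compound 3 in one place: hydrogen in place of propoxy on an aromatic carbon. Within the data shown here, no pair of measured compounds isolates this change; compound 1 and compound 2 differ from compound 3 in more than one place, so their numbers say nothing direct about it. With only the low number of compound 3, 7%, as a footing, the step from compound 3 to compound 4 is expected to stay within the scatter, estimated as a number 3 percentage points higher from compound 3 to compound 4 (within the scatter). Compound 4 is accordingly expected to give about 10% in this assay, with a range from 0% to 28%.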

Compound 4, a percentage reported as inhibition, in the whole organism at one dose (the size of the read-out at that dose, not a potency): 11%
Estimate against measurement, compound 4: 1 percentage points below; measured number inside the range.
By their numbers in this assay, from the lowest: compounds 3, 1 and 4 (each within the scatter of the next); then compound 2.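

In this assay, hydrogen in place of propoxy on the aromatic carbon opposite the ring nitrogen gives a number 4 percentage points higher from compound 3 to compound 4 (within the scatter), the first reading of a single change among these compounds. The propoxy group can therefore be removed from this position without a shift beyond the scatter, although this pair, with both numbers low, shows only how the change behaves where the effect at this dose is already small. No measurement at hand offers a reason for this result.

As far as these compounds go, whether a carboxylic acid or a longer chain such as butoxy on this carbon would raise the number remains open. Also open, from the compounds shown here alone, is whether removing the methoxy group of compound 2, which gives 29%, would likewise leave the number within the scatter.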